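A few compounds are considered here, and "the series" means these few. Any claim that something is new, unique, unknown or untested is made for them only; others in the source may bear on it.

Measured in a functional assay on Hep 3B2 cells (Homo sapiens) for cytotoxicity, read by MTT assay; a lower number here means a stronger inhibitor, a higher number a weaker inhibitor:
- Compound 1 `CC(=O)N1CCC(C[C@@H](c2nc3ccc(C)cc3n2C)N2C(=O)CN(c3ccc(Oc4ccccc4)cc3)C2=O)CC1`: 17200 nM
- Compound 2 `Cc1ccc2nc([C@H](CC3CCN(C(=O)C(C)C)CC3)N3C(=O)CN(c4ccc(Oc5ccccc5)cc4)C3=O)n(C)c2c1`: > 100000 nM, a limit and not a number
- Compound 3 `Cc1ccc2nc([C@H](CC3CCN(C(=O)C4CCCC4)CC3)N3C(=O)CN(c4ccc(Oc5ccccc5)cc4)C3=O)n(C)c2c1`: > 100000 nM, a limit and not a number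

Compound 2 stands at the limit of > 100000 nM in this assay, at which 2 of the 3 values shown sit. Compound 4 `CC(C)C(=O)N1CCC(C[C@@H](c2nc3ccccc3n2C)N2C(=O)CN(c3ccc(Oc4ccccc4)cc3)C2=O)CC1` differs from it by one change: hydrogen in place of methyl on an aromatic carbon. Among the compounds with values here, no measured step makes this change. The nearest steps, an at least 5.8-fold higher number from compound 1 to compound 2 (0.76 log units; beyond the scatter) and an at least 5.8-fold higher number from compound 1 to compound 3 (0.76 log units; beyond the scatter), replace the methyl on a carbonyl carbon instead, and a step that the two limits leave unreadable from compound 2 to compound 3 is also a change at that carbonyl. Compound 4 keeps the isopropyl that came with an at least 5.8-fold higher number from compound 1 to compound 2 (0.76 log units; beyond the scatter), so no step beyond the scatter is expected. The expected size is a number no higher from compound 2 to compound 4 (the limit leaves the size open). For compound 4 the estimated value is 100000 nM, with an expected range of 40000 nM to 250000 nM.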

Compound 4, half-maximal inhibitory concentration: > 100000 nM
Compound 4 gave a limit, no number; the forecaster's own chance of this, stated with the estimate: 70%; the middle value lies on the limit itself.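

Compound 2 and compound 4 both give a limit rather than a number in this assay, so no step can be read between them: the limit of > 100000 nM in this assay, at which 3 of the 4 values shown sit.

From the compounds shown here alone, whether replacing this methyl with hydrogen changes the value at all stays open.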